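The source may hold more compounds than are shown below. What is called first, only, known or untested is meant among the compounds shown, and "the series" means these compounds.

Compound 1 `COc1ccc(OCCCON2C(N)=NC(N)=NC23CCOCC3)cc1` and compound 2 `NC1=NC2(CCSCC2)N(OCCCOc2cc(Cl)c(Cl)cc2Cl)C(N)=N1` share a core that carries two amino groups on a ring bearing a spiro-linked saturated ring, with an oxygen-linked three-carbon chain leading to a substituted benzene ring. Both were tested in a functional assay on MDA-MB-231 cells (Homo sapiens) for antiproliferative activity, read by MTT assay, with a stated time of 72 h; a higher number here means a weaker inhibitor, a lower number a stronger inhibitor. For compound 1 the assay gives "not determined" (no result reported), so no number exists for where it stands; the only measured point in this series is compound 2, which in this assay gives 110 nM. Compound 3 `NC1=NC2(CCOCC2)N(OCCCOc2cccc(Br)c2)C(N)=N1` has not been measured. It differs from compound 1 in one place: 3-bromophenyl in place of 4-methoxyphenyl on an oxygen on a saturated carbon. For the measured compounds named here, compound 1 itself has no number, so no step can be sized from it, and the expectation for compound 3 must lean on the single value of compound 2 110 nM together with the fact that compound 3 carries a lighter halogen pattern and a different spiro ring than compound 2. The expected direction is toward a somewhat weaker inhibitor than compound 2, by a margin larger than the usual scatter but not a dramatic one. Compound 3 is therefore estimated at 350 nM, with a likely range from 70 nM to 1800 nM.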

Compound 3, half-maximal inhibitory concentration: 400 nM
Beside the measured number, compound 3's estimate is 1.1-fold (0.06 log units) below it, and the stated range covers the measured number.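

In this assay compound 1 gives "not determined" (no result reported) and so no step can be read from compound 1 to compound 3. As far as these compounds go, what replacing 4-methoxyphenyl with 3-bromophenyl does to antiproliferative activity therefore stays open. No measured evidence shown here offers an explanation for the result of compound 3.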